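The source may report more compounds than this note shows. Statements on the series, on what has been measured and on what is new or still open speak of the compounds shown alone.

Measured in a functional assay on HeLa cells (Homo sapiens) for cytotoxicity, read by MTT assay; on this read-out lower numbers stand for stronger inhibition and higher numbers for weaker inhibition:
- compound 1 `CC(=O)OCCC(=O)O[C@H](CC=C(C)C)C1=CC(=O)c2c(O)ccc(O)c2C1=O`: 17300 nM
- compound 2 `CCCC(C)(O)CC(=O)O[C@H](CC=C(C)C)C1=CC(=O)c2c(O)ccc(O)c2C1=O`: 72000 nM

Going by the values given here, compound 2 holds the higher of the two numbers in this assay, and compound 1 is its only measured neighbour. The next compound to consider is compound 3 `CC(C)=CC[C@@H](OCCO)C1=CC(=O)c2c(O)ccc(O)c2C1=O`. The change is 2-hydroxyethyl in place of (2-hydroxy-2-methylpentyl)carbonyl on an oxygen on a saturated carbon.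

Among the compounds with values here, only one measured step bears on this, a 4.2-fold higher number from compound 1 to compound 2 (0.62 log units; beyond the scatter). That modest step, beyond the scatter, exchanges 1-hydroxy-1-methylbutyl for acetoxymethyl and keeps the carbonyl carbon in both compounds. Within the data shown here, it shows that the number in this assay can move with this side chain, but no measured compound lacks that carbonyl, so the present replacement is untested. Among the measured compounds shown here, with only two values to go on, compound 2 at 72000 nM sits at the upper end of what has been seen, and a move toward lower numbers seems more likely than a further rise.

The expected change is a 3.6-fold lower number from compound 2 to compound 3 (0.56 log units; beyond the scatter), similar in size to the measured step. For compound 3 the estimate is 20000 nM, with an expected range of 6000 nM to 65000 nM.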

Compound 3, half-maximal inhibitory concentration: 18600 nM
Beside the measured number, compound 3's estimate is 1.1-fold (0.03 log units) above it, and the stated range covers the measured number.
By their numbers in this assay, from the lowest: compounds 1 and 3 (each within the scatter of the next); then compound 2.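

In this assay, the carbonyl on this oxygen is not needed to hold the number at the level of the ester series: 2-hydroxyethyl in place of (2-hydroxy-2-methylpentyl)carbonyl gives a 3.9-fold lower number from compound 2 to compound 3 (0.59 log units; beyond the scatter). Going by these compounds alone, the other ester offers a different reading, as 2-hydroxyethyl in place of (2-acetoxyethyl)carbonyl gives a 1.1-fold higher number from compound 1 to compound 3 (0.03 log units; within the scatter), so removing the carbonyl does not by itself separate the numbers, and only the pair containing the (2-hydroxy-2-methylpentyl)carbonyl group shows a difference beyond the scatter. No supporting data are available to account for either comparison.

The three compounds leave open whether any group on this oxygen brings the number in this assay below the level shared by the (2-acetoxyethyl)carbonyl and 2-hydroxyethyl groups, and whether the hydroxyl of 2-hydroxyethyl contributes to that level at all. A plain ethyl group, a longer chain carrying the same terminal hydroxyl, or a chain ending in an amine or a carboxylic acid on the same oxygen would test chain length and end group apart from the carbonyl.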